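Hydroxy for methyl on the saturated ring of compound 1

The source may hold more compounds than are shown below. What is called first, only, known or untested is meant among the compounds shown, and "the series" means these compounds.

Compound 1 `COc1cc([C@@H]2CC(C)(C)[C@@H]3CC=C(C)[C@@H](O)[C@@H]3O2)cc(OC)c1OC` gives 13% in a functional assay on the whole organism (Abdomen, strain albino) for inhibition, with Mus musculus as the target, with stated times of 1 h and 8 min, at a dose of 10 mg/kg by the oral route (a lower number here means less inhibition, a higher number more inhibition at the dose given (going by the name of the read-out)), and compound 2 `COc1cc(OC)c([C@@H]2CC(C)(O)[C@@H]3CC=C(C)[C@@H](O)[C@@H]3O2)c(OC)c1` gives 13% in this assay; the two stand level within the scatter. Compound 3 `COc1cc([C@@H]2CC(C)(O)[C@@H]3CC=C(C)[C@@H](O)[C@@H]3O2)cc(OC)c1OC` remains to be measured in this assay. It differs from compound 1 by hydroxy in place of methyl on a saturated ring carbon. Among the measured compounds shown here, no step between measured compounds is available to gauge this change; the values of compound 1 and compound 2 show a low level throughout, so no step beyond the scatter is expected. Compound 3 is expected to give 13%, within a range from 0% to 28%. The expected step is no change at the digits printed from compound 1 to compound 3 (within the scatter).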

Compound 3, a percentage reported as inhibition, in the whole organism at one dose (the size of the read-out at that dose, not a potency): 16%
For compound 3 the middle estimate is 3 percentage points below the measured one; the measured number falls inside the stated range.
By their numbers in this assay, from the lowest: compounds 1, 2 and 3 (each within the scatter of the next).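

In this assay hydroxy in place of methyl on a saturated ring carbon gives a number 3 percentage points higher from compound 1 to compound 3 (within the scatter) at this position, the first step read at this carbon. The change brings in a hydrogen-bond donor and acceptor here, yet the inhibition at the dose given stays at the low level of the series. No measured data bear on a reason for this result. From the compounds shown here alone, whether an amine or a carboxylic acid on this carbon would move the read-out beyond the scatter stays open. The compounds shown also leave open whether any change at this position can raise the inhibition.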